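The source may report more compounds than this note shows. Statements on the series, on what has been measured and on what is new or still open speak of the compounds shown alone.

Measured compounds:
- compound 1 `c1ccc(CNC[C@@H]2COC[C@H](c3ccccc3)O2)cc1` — 155 nM
- compound 2 `c1ccc(CNC[C@H]2COC[C@H](c3ccccc3)O2)cc1` — 542 nM
- compound 3 `c1ccc(CNCCC2COCC(c3ccccc3)(c3ccccc3)O2)cc1` — 502 nM

In an assay on membranes from brain for displacement of a labelled ligand from Sigma non-opioid intracellular receptor 1 (Cavia porcellus), read by scintillation counting, with a stated time of 120 min, in the presence of a further agent that is not named here (on this read-out higher numbers stand for weaker inhibition and lower numbers for stronger inhibition), compound 3 stands second highest of the three numbers. Its nearest neighbour is compound 2, whose value is within the scatter of compound 3; the furthest is compound 1, which lies beyond the scatter with the lower number. Within the data shown here, the only measured step is a 3.5-fold higher number from compound 1 to compound 2 (0.54 log units; beyond the scatter), which rests on the fact that compounds 1 and 2 differ only in the configuration as drawn and says nothing about chain length.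

Compound 4 `c1ccc(CNCC2COCC(c3ccccc3)(c3ccccc3)O2)cc1` differs from compound 3 by benzylamino in place of (benzylamino)methyl on a saturated chain carbon bound to a saturated ring carbon. Among the measured compounds shown here, no measured pair of compounds shares this change, so no step of known size bears on it. Compounds 1 and 2 carry a differently substituted core and differ from compound 3 in more than one place; their values only show the span of numbers seen so far in this assay.

For the measured compounds named here, with no step to lean on, the expectation for compound 4 is a value close to compound 3, with the step of a 1.1-fold lower number from compound 3 to compound 4 (0.05 log units; within the scatter) estimated to lie within the scatter. Compound 4 is therefore estimated at 450 nM in this assay, with a range from 150 nM to 1400 nM.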

Compound 4, inhibition constant: 4900 nM
For compound 4 the middle estimate is 11-fold (1.04 log units) below the measured one; the measured number lies above the stated range.
By their numbers in this assay, from the lowest: compound 1; then compounds 3 and 2 (each within the scatter of the next); then compound 4.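

In this assay, benzylamino in place of (benzylamino)methyl on a saturated chain carbon bound to a saturated ring carbon reads as a 9.8-fold higher number from compound 3 to compound 4 (0.99 log units; beyond the scatter), the first measured size for this change. This position therefore responds to the change on the core shared by compound 3 and compound 4, even though the hydrogen-bond donor and acceptor counts of the two groups are the same; the earlier step showed only a change in configuration on a different core. Nothing in the information available accounts for the size of this step.

Going by these compounds, whether the same change has a similar effect on the core of compound 1 remains open. So does the outcome with a longer chain such as (benzylamino)propyl, or with a tertiary amine in place of the benzylamino nitrogen.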